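Swapping the piperazine substituent: from bromobenzyl back to fluorophenyl

The source may report more compounds than this note shows. Statements on the series, on what has been measured and on what is new or still open speak of the compounds shown alone.

Measured so far:
- compound 1 `CCCn1c(=O)[nH]c2nc(-c3ccc(S(=O)(=O)N4CCN(c5ccc(F)cc5)CC4)cc3)[nH]c2c1=O`: 38%
- compound 2 `CCCn1c(=O)[nH]c2nc(-c3ccc(S(=O)(=O)N4CCN(Cc5cccc(Br)c5)CC4)cc3)[nH]c2c1=O`: 23%

Both compounds were tested in an assay on CHO cells for displacement of a labelled ligand from adenosine receptor A3 (Homo sapiens), read by scintillation counting, with a stated time of 45 min, tested at 1 uM, in the presence of a further agent that is not named here; a lower number here means less inhibition, a higher number more inhibition at the concentration tested (going by the name of the read-out). Among the measured compounds shown here, compound 2 stands lowest of the two numbers: the only measured step, a number 15 percentage points lower from compound 1 to compound 2 (beyond the scatter), lies beyond the scatter, so compound 2 shows less displacement than compound 1.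

Compound 3 `CCCn1c(=O)[nH]c2nc(-c3ccc(S(=O)(=O)N4CCN(c5ccccc5F)CC4)cc3)[nH]c2c1=O` has not yet been measured. It differs from compound 2 by 2-fluorophenyl in place of 3-bromobenzyl on an amine nitrogen in a ring. For the measured compounds named here, the one measured step bears directly on this: it shows what happened when the 4-fluorophenyl of compound 1 gave way to 3-bromobenzyl, a modest drop. Compound 3 reverses the benzyl-for-aryl part of that change, though with fluorine at a different position, for which no measurement exists. The expectation is therefore a modest rise, a number 12 percentage points higher from compound 2 to compound 3 (beyond the scatter), bringing compound 3 back toward compound 1, with wide uncertainty. The estimated value for compound 3 is 35%, within a range of 15% to 55%.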

Compound 3, a percentage reported as inhibition, at one concentration (the size of the read-out at that concentration, not a potency): 9%
Estimate against measurement, compound 3: 26 percentage points above, and the stated range ends above it.
By their numbers in this assay, from the lowest: compound 3; then compound 2; then compound 1.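

In this assay, changing only where the fluorine sits, with 2-fluorophenyl in place of 4-fluorophenyl on the ring nitrogen, gives a number 29 percentage points lower from compound 1 to compound 3 (beyond the scatter). This shows that the two fluorophenyl groups are not interchangeable at this position. Putting 2-fluorophenyl in place of 3-bromobenzyl gives a number 14 percentage points lower from compound 2 to compound 3 (beyond the scatter), while compound 1 reads above compound 2, so a fluorophenyl here can read either above or below the 3-bromobenzyl, and nothing available explains this difference.

Still open, going by these compounds, is where a plain phenyl, a 4-chlorophenyl or a 2-fluorobenzyl would fall on this nitrogen. On these data alone, all three readings also come from a single concentration, so how far they reflect differences in potency remains unknown.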